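Cytotoxicity notes: from compound 1 to compound 3

A few compounds are considered here, and "the series" means these few. Any claim that something is new, unique, unknown or untested is made for them only; others in the source may bear on it.

Going by the values given here, in a functional assay on MT4 cells (Homo sapiens) for cytotoxicity (a higher number here means that more compound is tolerated, a lower number that less compound is tolerated), compound 1 (`CC(C)(C)[Si](C)(C)OC[C@H]1O[C@@H](n2cnc3c(O)ncnc32)[C@H](O[Si](C)(C)C(C)(C)C)[C@]12OS(=O)(=O)C=C2N`) gives 14000 nM, the lower of the two numbers measured so far. Compound 2 (`COc1ccc(C(Nc2ncnc3c2ncn3[C@@H]2O[C@H](CO[Si](C)(C)C(C)(C)C)[C@@]3(OS(=O)(=O)C=C3N)[C@H]2O[Si](C)(C)C(C)(C)C)(c2ccccc2)c2ccccc2)cc1`) gives 192000 nM, a higher number by a margin beyond the scatter. Compound 3 (`CC(C)(C)[Si](C)(C)OC[C@H]1O[C@@H](n2cnc3ccccc32)[C@H](O[Si](C)(C)C(C)(C)C)[C@]12OS(=O)(=O)C=C2N`) is not yet measured. It departs from compound 1 on a saturated ring carbon of a five-membered non-aromatic ring with 1 oxygen, where 1H-benzimidazol-1-yl enters: a group of 9 heavy atoms (7 carbon, 2 nitrogen; one five-membered aromatic ring with 2 hetero atoms, one six-membered aromatic ring of carbon only) in place of a group of 10 heavy atoms (5 carbon, 4 nitrogen, 1 oxygen; one five-membered aromatic ring with 2 hetero atoms, one six-membered aromatic ring with 2 hetero atoms), on a saturated ring carbon. No measured pair isolates this kind of change, and the data give no reason to favour a direction. The expectation therefore stays anchored on compound 1 at 14000 nM. A change no larger than the scatter is expected in this assay, with an estimated 1.3-fold higher number from compound 1 to compound 3 (0.11 log units; within the scatter). For compound 3 the estimate is 18000 nM, with an expected range of 6000 nM to 70000 nM.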

Compound 3, half-maximal cytotoxic concentration: 15000 nM
The estimate for compound 3 lay 1.2-fold (0.08 log units) above the measured number, within the range that was stated.
By their numbers in this assay, from the lowest: compounds 1 and 3 (each within the scatter of the next); then compound 2.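

In this assay the exchange at the saturated ring carbon next to the ring oxygen gives a 1.1-fold higher number from compound 1 to compound 3 (0.03 log units; within the scatter), so replacing the group of compound 1 with 1H-benzimidazol-1-yl leaves the tolerated concentration within the scatter. At this position, then, tolerance in MT4 cells does not separate the two fused bicyclic groups, even though the entering group has a six-membered aromatic ring of carbon only and 0 hydrogen-bond donors. No supporting measurement bears on why the two groups read alike.

The compounds shown leave open whether this tolerance extends beyond fused bicyclic groups, for example to a single phenyl ring or an open-chain amine at this carbon. They also leave open whether the same exchange would read alike on a core without the two tert-butyldimethylsilyl groups.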